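This account rests on a few compounds, and the source may have more. Where it says the series, first, only, none or still open, it means among the compounds named here.

Measured compounds:
compound 1 `Cc1ccc(C2=NN(C3=NC(c4ccccc4)CS3)C(c3ccc4ccccc4c3)C2)cc1C`, 7370 nM in a functional assay on HepG2 cells (Homo sapiens) for inhibition, read by CCK-8 assay, with a stated time of 48 h; on this read-out lower numbers stand for stronger inhibition and higher numbers for weaker inhibition
compound 2 `Cc1ccc(C2=NN(C3=NC(=O)CS3)C(c3ccc4ccccc4c3)C2)cc1C`, 8490 nM
compound 3 `Brc1ccc(C2=NN(C3=NC(c4ccccc4)CS3)C(c3cccc4ccccc34)C2)cc1`, 15600 nM

Compound 2 arises from compound 1 by one change, (a group of 6 heavy atoms (3 carbon, 1 nitrogen, 1 oxygen, 1 sulfur; one five-membered non-aromatic ring with 2 hetero atoms) in place of a group of 11 heavy atoms (9 carbon, 1 nitrogen, 1 sulfur; one five-membered non-aromatic ring with 2 hetero atoms, one six-membered aromatic ring of carbon only), on an amine nitrogen in a ring), and this gave a 1.2-fold higher number from compound 1 to compound 2 (0.06 log units; within the scatter). The same kind of change turns compound 3 into the unmeasured compound 4 `O=C1CSC(N2N=C(c3ccc(Br)cc3)CC2c2cccc3ccccc23)=N1`, namely (a group of 6 heavy atoms (3 carbon, 1 nitrogen, 1 oxygen, 1 sulfur; one five-membered non-aromatic ring with 2 hetero atoms) in place of a group of 11 heavy atoms (9 carbon, 1 nitrogen, 1 sulfur; one five-membered non-aromatic ring with 2 hetero atoms, one six-membered aromatic ring of carbon only), on an amine nitrogen in a ring). It is the same kind of change rather than the same one, since the surroundings differ: in compound 1 the changed nitrogen sits next to the ring atom that bears a naphthalen-2-yl group and two ring bonds from the ring atom that bears a 3,4-dimethylphenyl group, whereas in compound 3 it sits next to the ring atom that bears a naphthalen-1-yl group and two ring bonds from the ring atom that bears a 4-bromophenyl group. How the core of compound 1 and the core of compound 3 differ is not broken down here. Compound 3 and compound 2 lie within the scatter of each other, while compound 3 stands beyond the scatter from compound 1.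

Because the earlier change gave a 1.2-fold higher number from compound 1 to compound 2 (0.06 log units; within the scatter), a step of similar, small size is expected for compound 4, a 1.2-fold higher number from compound 3 to compound 4 (0.06 log units; within the scatter). Compound 4 is therefore estimated at 18000 nM in this assay, with a likely range from 8000 nM to 40000 nM.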

Compound 4, half-maximal inhibitory concentration: 13400 nM
Beside the measured number, compound 4's estimate is 1.3-fold (0.13 log units) above it; measured number inside the range.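

In this assay, putting the group of 6 heavy atoms in place of the group of 11 heavy atoms, which also removes its six-membered aromatic ring of carbon only, gives a 1.2-fold lower number from compound 3 to compound 4 (0.07 log units; within the scatter), so the swap leaves the number within the scatter on this core as well. The step agrees with the earlier one, and the change behaves alike on both cores: the same change on two cores in this assay, a 1.2-fold higher number (0.06 log units; within the scatter) from compound 1 to compound 2 and a 1.2-fold lower number (0.07 log units; within the scatter) from compound 3 to compound 4, 1.3-fold (0.13 log units) apart, within the scatter of two such steps. This shows that, in these two pairs, the smaller group can stand in for the larger one without a measurable shift, but two pairs cannot give the change a direction, cannot show that it would stay this small on every core in the series, and say nothing about effects outside this assay.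

The compounds shown leave open whether a group carrying an amine or a carboxylic acid on the same ring nitrogen would move the number beyond the scatter. They also leave open whether the result holds on cores bearing aryl groups other than those shown here.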